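A few compounds are considered here, and "the series" means these few. Any claim that something is new, unique, unknown or untested is made for them only; others in the source may bear on it.

Compound 1 `CC(C)c1nc(C(C)(C)C)cc(-c2ccc(F)cc2)c1/C=C/[C@@H]1C[C@@H](O)CC(=O)O1` is the weaker of the two measured compounds: in an assay on HepG2 cells for inhibition of 3-hydroxy-3-methylglutaryl-coenzyme A reductase (Homo sapiens) (a lower number here means a stronger inhibitor, a higher number a weaker inhibitor), compound 1 gives 20 nM, the highest number among the two, while compound 2 `CC(C)c1nc(-c2ccc(F)cc2)cc(-c2ccc(F)cc2)c1/C=C/[C@@H]1C[C@@H](O)CC(=O)O1` gives 7.5 nM in this assay, a step of a 2.7-fold lower number from compound 1 to compound 2 (0.43 log units; beyond the scatter) that comes from placing a 4-fluorophenyl group on the aromatic carbon that had carried tert-butyl.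

Compound 3 `Cc1ccc(C)c(-c2cc(-c3ccc(F)cc3)c(/C=C/[C@@H]3C[C@@H](O)CC(=O)O3)c(C(C)C)n2)c1` takes the same aromatic carbon of compound 1, next to the ring nitrogen, and changes it as follows: 2,5-dimethylphenyl in place of tert-butyl on an aromatic carbon. Among the measured compounds shown here, the one measured step that bears on this change is the one from compound 1 to compound 2, where an aromatic ring in place of tert-butyl on that carbon gave a modest improvement beyond the scatter. The entering ring in compound 3 carries two methyl groups rather than a fluorine, so the step is not the same, but it is of the same kind.

Compound 3 is therefore expected to show a step of a 2.0-fold lower number from compound 1 to compound 3 (0.30 log units; within the scatter) in this assay, in the direction of stronger inhibition, because the measured step of a 2.7-fold lower number from compound 1 to compound 2 (0.43 log units; beyond the scatter) went that way. The estimate for compound 3 in this assay is 10 nM, with a range from 4 nM to 25 nM.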

Compound 3, half-maximal inhibitory concentration: 20 nM
The estimate for compound 3 lay 2.0-fold (0.30 log units) below the measured number, and the stated range covers the measured number.
By their numbers in this assay, from the lowest: compound 2; then compounds 1 and 3 (each within the scatter of the next).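

At this aromatic carbon next to the ring nitrogen, an aromatic ring in place of tert-butyl does not by itself bring a gain in this assay: 2,5-dimethylphenyl in place of tert-butyl gives no change at the digits printed from compound 1 to compound 3 (within the scatter) and so leaves the number where tert-butyl had it. What now separates the compounds is the choice of aromatic ring, since 2,5-dimethylphenyl in place of 4-fluorophenyl gives a 2.7-fold higher number from compound 2 to compound 3 (0.43 log units; beyond the scatter) and the improvement seen earlier therefore belongs, among these three compounds, to 4-fluorophenyl and not to any aromatic ring at this place. Nothing measured here accounts for the difference between the two rings.

The compounds shown leave open whether the fluorine or the two methyl groups set this gap, for neither an unsubstituted phenyl nor a ring bearing a single methyl group stands among them. They also say nothing of how this carbon responds to a group that is neither a hydrocarbon nor a fluorinated aromatic ring, such as an amine, a methoxy group or a carboxylic acid.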